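Taking the chloro group off compound 2

A few compounds are considered here, and "the series" means these few. Any claim that something is new, unique, unknown or untested is made for them only; others in the source may bear on it.

In a functional assay on MCF7 cells (Homo sapiens) for cytotoxicity, read by MTT assay, with a stated time of 48 h (a higher number here means a weaker inhibitor, a lower number a stronger inhibitor), compound 1 `C/C(=N\NC(=S)Nc1ccc(I)cc1)c1ccccn1` gives 6.61 nM. Going by the values given here, compound 2 `C/C(=N\NC(=S)Nc1ccccc1Cl)c1ccccn1` gives 0.16 nM, the lower of the two numbers so far, and the gap between the two values lies beyond the scatter. Compound 3 `C/C(=N\NC(=S)Nc1ccccc1)c1ccccn1` is still to be measured in this assay. Its structure differs from that of compound 2 by hydrogen in place of chloro on an aromatic carbon.

Among the compounds with values here, no measured pair shows a change of this kind. Compound 1 and compound 2 differ in more than one place, so their gap cannot be assigned to the chloro group alone. Within the data shown here, with only two values available, the working expectation places compound 3 between compound 2 at 0.16 nM and compound 1 at 6.61 nM. The expected change is a 7.5-fold higher number from compound 2 to compound 3 (0.88 log units; beyond the scatter), towards a weaker inhibitor and probably beyond the scatter, although its size is poorly defined. For compound 3 the estimated value is 1.2 nM, with an expected range of 0.15 nM to 10 nM.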

Compound 3, half-maximal inhibitory concentration: 0.18 nM
Compound 3: middle estimate off by 6.7-fold (0.82 log units), on the high side, within the range that was stated.
By their numbers in this assay, from the lowest: compounds 2 and 3 (each within the scatter of the next); then compound 1.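

In this assay, replacing the chloro group on this aromatic carbon, ortho to a large group, with hydrogen gives a step within the scatter: a 1.1-fold higher number from compound 2 to compound 3 (0.05 log units; within the scatter). This first single-place reading at this position shows that the low number of compound 2 does not depend on the chloro group, since compound 3 carries only hydrogen there. The other single-place reading, where the iodo group gives way to hydrogen, is large, a 37-fold lower number from compound 1 to compound 3 (1.56 log units; beyond the scatter), so the iodo group of compound 1 and the chloro group of compound 2 do not behave alike when each is replaced by hydrogen, and no supporting measurement on these compounds bears on either step.

The compounds shown leave open whether the ring carbon ortho to the large group would accept something other than a single halogen or hydrogen, such as a methoxy group, an amine or a carboxylic acid, with as little effect on the number. They also leave open whether a chloro or bromo group placed on the aromatic carbon that carries iodo in compound 1 would give a step as large as the one seen for iodo.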